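Compound 3 to compound 4: one more cyanomethyl

A few compounds are considered here, and "the series" means these few. Any claim that something is new, unique, unknown or untested is made for them only; others in the source may bear on it.

Three compounds share one core and differ in the group on the carbonyl carbon, measured in a functional assay on PC-3 cells (Homo sapiens), read by MTT assay, with a stated time of 48 h; on this read-out lower numbers stand for stronger inhibition and higher numbers for weaker inhibition:

compound 1 `CCN(CC)CCCNC(=O)c1ccc(C(CC)(CC)c2ccc(OCC(O)C(C)(C)C)c(C)c2)n1CC` gives 2500 nM
compound 2 `CCn1c(C(=O)NCC(OC)OC)ccc1C(CC)(CC)c1ccc(OCC(O)C(C)(C)C)c(C)c1` gives 14600 nM
compound 3 `CCn1c(C(=O)N(C)CCC#N)ccc1C(CC)(CC)c1ccc(OCC(O)C(C)(C)C)c(C)c1` gives 1700 nM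

Compound 3 stands at the low end of these numbers, level within the scatter with compound 1 and clearly under compound 2. Compound 4 `CCn1c(C(=O)N(CCC#N)CCC#N)ccc1C(CC)(CC)c1ccc(OCC(O)C(C)(C)C)c(C)c1` carries cyanomethyl in place of hydrogen on a saturated chain carbon bound to an amide-type nitrogen. Within the data shown here, no measured step makes this exact change. The nearest guide is a 1.5-fold lower number from compound 1 to compound 3 (0.17 log units; within the scatter), which stays within the scatter, while the larger 8.6-fold lower number from compound 2 to compound 3 (0.93 log units; beyond the scatter) shows that changes on the carbonyl carbon can reach a modest size. The expected change is small, with no clear direction, and is estimated as a 1.2-fold higher number from compound 3 to compound 4 (0.07 log units; within the scatter). Compound 4 is expected at 2000 nM, within a range of 700 nM to 6000 nM.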

Compound 4, half-maximal inhibitory concentration: 7800 nM
The estimate for compound 4 lay 3.9-fold (0.59 log units) below the measured number; measured number above the stated range.
By their numbers in this assay, from the lowest: compounds 3 and 1 (each within the scatter of the next); then compounds 4 and 2 (each within the scatter of the next).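

In this assay, cyanomethyl in place of hydrogen on a saturated chain carbon bound to an amide-type nitrogen proves not to be a neutral change, giving a 4.6-fold higher number from compound 3 to compound 4 (0.66 log units; beyond the scatter). This leaves compound 4 within the scatter of compound 2, with a 1.9-fold lower number from compound 2 to compound 4 (0.27 log units; within the scatter), but clearly apart from compound 1, with a 3.1-fold higher number from compound 1 to compound 4 (0.49 log units; beyond the scatter). No measurement shown here bears on why this change has this effect. The compounds shown leave open how a longer chain, an amine or a carboxylic acid would read at this place in place of cyanomethyl.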